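This account rests on a few compounds, and the source may have more. Where it says the series, first, only, none or still open, it means among the compounds named here.

Compound 1 `COc1ccc(N(C)c2nc(C)nc3ccccc23)cc1C(=O)OCCCCC[Se]C#N` and compound 2 `COc1ccc(N(C)c2nc(C)nc3ccccc23)cc1OCCCCC[Se]C#N` share one core and differ in how the selenocyanate-bearing chain is attached. In a functional assay on RKO cells (Homo sapiens) for inhibition, read by MTT assay, with a stated time of 48 h (a higher number here means a weaker inhibitor, a lower number a stronger inhibitor), compound 1 gives 356 nM, while compound 2 gives 3560 nM, the higher of the two numbers, with compound 1 lying well beyond the scatter on the lower side. Compound 3 `COc1ccc(N(C)c2nc(C)nc3ccccc23)cc1C[Se]C#N` has not yet been measured in this assay. Its change from compound 2 is a group of 4 heavy atoms (2 carbon, 1 nitrogen, 1 selenium; no ring) in place of a group of 9 heavy atoms (6 carbon, 1 nitrogen, 1 oxygen, 1 selenium; no ring), on an aromatic carbon, at the place ortho to a methoxy group and meta to a large group. Going by the values given here, no measured pair shows this kind of shortening, so the expectation rests on the two numbers alone. Compound 3 is expected to give about 1500 nM, with a range from 300 nM to 8000 nM. This corresponds to an expected step of a 2.4-fold lower number from compound 2 to compound 3 (0.38 log units; beyond the scatter) toward a lower number, roughly at the edge of the scatter.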

Compound 3, half-maximal inhibitory concentration: 316 nM
Compound 3: the middle estimate sits 4.7-fold (0.68 log units) above what was measured; the measured number falls inside the stated range.
By their numbers in this assay, from the lowest: compounds 3 and 1 (each within the scatter of the next); then compound 2.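

In this assay, the group of 4 heavy atoms in place of the group of 9 heavy atoms gives an 11-fold lower number from compound 2 to compound 3 (1.05 log units; beyond the scatter), so at this place, ortho to a methoxy group, shortening the chain does not cost activity on these cells but goes with a large gain. The long chain is therefore not needed for a low number here: compound 3, with the short group, gives 316 nM, within the scatter of compound 1 at 356 nM. Nothing available here explains why the shorter group gives the lower number.

The change removes chain length and the oxygen link together, so an all-carbon chain of intermediate length would be needed to tell them apart. On these data alone, whether selenium itself matters also stays open, and a thiocyanate in place of the selenocyanate would address that.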